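Cytotoxicity notes: fluoro to trifluoromethyl on the aryl ring

The source may report more compounds than this note shows. Statements on the series, on what has been measured and on what is new or still open speak of the compounds shown alone.

Measured so far in an ADME assay on HEK-293T cells (Homo sapiens) for cytotoxicity, read by MTT assay, with a stated time of 24 h; a higher number here means that more compound is tolerated, a lower number that less compound is tolerated:
- compound 1 `O=C(c1ccncc1)n1c(-c2cn(-c3ccccc3)nc2-c2ccc(F)cc2)nc2ccccc21` gives 151000 nM
- compound 2 `O=C(c1cccnc1)n1c(-c2cn(-c3ccccc3)nc2-c2ccc(F)cc2)nc2ccccc21` gives 216000 nM

Going by the values given here, compound 2 holds the highest of the two numbers, and its nearest neighbour is compound 1; the only step available, a 1.4-fold higher number from compound 1 to compound 2 (0.16 log units; within the scatter), is a change of the pyridyl attached to the carbonyl carbon and lies within the scatter. Both compounds are therefore tolerated to about the same degree.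

Compound 3 `O=C(c1cccnc1)n1c(-c2cn(-c3ccccc3)nc2-c2ccc(C(F)(F)F)cc2)nc2ccccc21` is the next member, not yet measured. It differs from compound 2 by trifluoromethyl in place of fluoro on an aromatic carbon. Among the compounds with values here, no measured step touches this position of the shared core: the one step known concerns the carbonyl substituent only, so nothing in the numbers so far speaks for or against a shift when fluoro becomes trifluoromethyl. The working expectation is accordingly that compound 3 stays within the scatter of compound 2, the expected step being a 1.1-fold lower number from compound 2 to compound 3 (0.03 log units; within the scatter). Compound 3 is estimated at 200000 nM, with a range from 80000 nM to 450000 nM.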

Compound 3, half-maximal cytotoxic concentration: 158000 nM
The estimate for compound 3 lay 1.3-fold (0.10 log units) above the measured number, and the stated range covers the measured number.
By their numbers in this assay, from the lowest: compounds 1, 3 and 2 (each within the scatter of the next).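

In this assay, going by these compounds alone, the change from 4-fluorophenyl to 4-(trifluoromethyl)phenyl gives a 1.4-fold lower number from compound 2 to compound 3 (0.14 log units; within the scatter) and so provides the first measured step at this position, on an aromatic carbon para to a large group. Going from fluoro, with 1 heavy atom, to trifluoromethyl, with 4 heavy atoms, therefore separates compound 2 and compound 3 by no more than the usual scatter, and neither group carries a hydrogen-bond donor or acceptor or a net charge. No measurement on hand explains this result or ties it to any property of either group.

Whether an amine, a carboxylic acid or a longer chain at this position would give a step beyond the scatter remains open, as the two groups shown here mark only a narrow part of what the position could hold. Also open, on these data alone, is whether the fluoro to trifluoromethyl step reads the same with pyridin-4-yl on the carbonyl carbon, as this step is read only with pyridin-3-yl in that place.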